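The source may hold more compounds than are shown below. What is called first, only, known or untested is meant among the compounds shown, and "the series" means these compounds.

In a functional assay on OVCAR-3 cells (Homo sapiens) for cytotoxicity, read by MTT assay, with a stated time of 6 days (on this read-out higher numbers stand for weaker inhibition and lower numbers for stronger inhibition), compound 1 `CC(=O)N[C@@H](CSC(=O)Nc1ccc(Br)cc1)C(=O)O` gives > 200000 nM as its result, and this is a limit of the assay, not a number. In the same test compound 2 `CC(=O)N[C@@H](CSC(=O)NCc1ccc(Cl)cc1)C(=O)O` gives > 200000 nM as its result, again a limit and not a number. The record so far comes down to the limit of > 200000 nM in this assay, at which 2 of the 2 values shown sit, with no exact number anywhere. Compound 1 therefore stands at that limit.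

Compound 3 `CC(=O)N[C@@H](CSC(=O)Nc1ccc(Cl)cc1)C(=O)O` differs from compound 1 in one place, with chloro in place of bromo on an aromatic carbon, para to a large group (chloro in place of bromo on an aromatic carbon). Among the measured compounds shown here, no step between measured compounds is available to size this swap. For the measured compounds named here, compound 1 with its limit of > 200000 nM is the only guide here, so no step beyond the usual scatter is expected in this assay and compound 3 will probably report the same limit. Put as a number, the estimated step is (a number no higher from compound 1 to compound 3 (the limit leaves the size open)). For compound 3 the estimated value is 200000 nM in this test, with an expected range from 100000 nM to 400000 nM if a number is reported at all.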

Compound 3, half-maximal inhibitory concentration in the OVCAR-3 assay: > 200000 nM
Compound 3: a limit, no number (the forecaster's own chance of this, stated with the estimate: 85%); the middle value lies on the limit itself.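

In the OVCAR-3 assay compound 1 gives > 200000 nM, and this is a limit and not a number. In the OVCAR-3 assay compound 3 gives > 200000 nM, again a limit and not a number. So chloro in place of bromo on the aromatic carbon gives no step that can be read: the limit of > 200000 nM in the OVCAR-3 assay, at which 3 of the 3 values shown sit. The compounds shown leave open how strongly, if at all, any of them acts on these cells, and whether this swap matters for that. In a physicochemical assay for solubility, in phosphate buffer, at pH 7.4 (on this read-out lower numbers stand for lower solubility and higher numbers for higher solubility), compound 1 gives 24 ug/mL and compound 3 gives 26 ug/mL, two values within the usual scatter of each other.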